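Inverting one ring stereocentre of compound 1

This account rests on a few compounds, and the source may have more. Where it says the series, first, only, none or still open, it means among the compounds named here.

Compound 1 `CC(=O)OC[C@H]1O[C@@H](Oc2nc(-c3cccs3)cc(-c3ccc(Cl)cc3)c2C#N)[C@H](OC(C)=O)[C@@H](OC(C)=O)[C@H]1OC(C)=O` gives 20% in a functional assay on MCF7 cells (Homo sapiens) for inhibition, read by MTT assay, with a stated time of 48 h, tested at 100 ug/mL (a higher number here means a stronger effect of the compound at the concentration tested, a lower number a weaker effect), the higher of the two numbers recorded; compound 2 `CC(=O)OC[C@H]1O[C@@H](Oc2nc(-c3cccs3)cc(-c3ccc(Cl)cc3)c2C#N)[C@H](OC(C)=O)[C@H]1OC(C)=O` gives 8% in this assay, a result that lies beyond the scatter below compound 1. Compound 3 `CC(=O)OC[C@H]1O[C@@H](Oc2nc(-c3cccs3)cc(-c3ccc(Cl)cc3)c2C#N)[C@H](OC(C)=O)[C@@H](OC(C)=O)[C@@H]1OC(C)=O` is not yet measured. It differs from compound 1 in this way: the two compounds have the same atoms and bonds and differ only in configuration as drawn: 1 of 5 stereo elements differ; a stereocentre at a saturated ring carbon is drawn S in compound 1 and R in compound 3. Among the measured compounds shown here, no pair of measured compounds shows such a step, so its size is unknown; since nothing leaves or enters, a step of no more than the scatter, in either direction, is expected a number 2 percentage points lower from compound 1 to compound 3 (within the scatter). Compound 3 is estimated at 18%, within 5% to 35%.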

Compound 3, a percentage reported as inhibition, at one concentration (the size of the read-out at that concentration, not a potency): 10%
Compound 3: middle estimate off by 8 percentage points, on the high side; the measured number falls inside the stated range.
By their numbers in this assay, from the lowest: compounds 2, 3 and 1 (each within the scatter of the next, the first and the last beyond it).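

Inverting this saturated ring carbon from S to R in this assay gives a number 10 percentage points lower from compound 1 to compound 3 (within the scatter) and is the first measured step at a stereocentre in this set. At this position, the change of configuration therefore does not move the read-out beyond the scatter, so no effect of it can be claimed. The comparison rests on one change alone: the fact that compounds 1 and 3 differ only in the configuration as drawn.

Going by these compounds, it remains open whether the other ring stereocentres behave alike. On these data alone, it also remains open whether free hydroxyl groups or an amine in place of the acetate esters would shift the read-out.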